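The source may hold more compounds than are shown below. What is called first, only, known or untested is meant among the compounds shown, and "the series" means these compounds.

Compound 1 `O=C(CCc1cccc2c1B(O)OC2)Nc1ccccc1`: 30000 nM
Compound 2 `O=C(CCc1cccc2c1B(O)OC2)Nc1cccc(-c2ccc(Cl)cc2)c1`: 9800 nM
Compound 3 `COc1ccc(-c2cccc(NC(=O)CCc3cccc4c3B(O)OC4)c2)cc1`: 1400 nM

These three compounds share a core and were tested in an ADME assay on WI-38 cells (Homo sapiens) for cytotoxicity, read by MTT assay, with a stated time of 72 h; on this read-out higher numbers stand for weaker inhibition and lower numbers for stronger inhibition. Compound 3, at 1400 nM, has the lowest number of the three, so it shows the strongest inhibition of the set. The next compound, compound 4 `CSc1cccc(-c2cccc(NC(=O)CCc3cccc4c3B(O)OC4)c2)c1`, has 3-(methylsulfanyl)phenyl in place of 4-methoxyphenyl, on an aromatic carbon that is meta to a large group: 3-(methylsulfanyl)phenyl in place of 4-methoxyphenyl on an aromatic carbon.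

Among the measured compounds shown here, three measured steps bear on this change. Adding a substituted phenyl group lowered the number both times, with a 3.1-fold lower number from compound 1 to compound 2 (0.49 log units; beyond the scatter) and a 21-fold lower number from compound 1 to compound 3 (1.33 log units; beyond the scatter). Compound 4 also carries such a group, so it should stay well under the value of compound 1. Changing only the substituent on that group still mattered, as a 7.0-fold lower number from compound 2 to compound 3 (0.85 log units; beyond the scatter) shows. For the measured compounds named here, no measured compound contains sulfur or has its substituent in this new place, so the evidence is indirect. A small rise in this assay is therefore expected, possibly none beyond the scatter. The expected change is a 1.8-fold higher number from compound 3 to compound 4 (0.25 log units; within the scatter). For compound 4 the estimated value is 2500 nM, with an expected range of 900 nM to 8000 nM.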

Compound 4, half-maximal inhibitory concentration: 2000 nM
Beside the measured number, compound 4's estimate is 1.3-fold (0.10 log units) above it, within the range that was stated.
By their numbers in this assay, from the lowest: compounds 3 and 4 (each within the scatter of the next); then compound 2; then compound 1.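

In this assay, the group on this aromatic carbon can go from 4-methoxyphenyl to 3-(methylsulfanyl)phenyl, with sulfur entering for oxygen and the substituent moving on the outer ring, and the two compounds still cannot be told apart (a 1.4-fold higher number from compound 3 to compound 4 (0.15 log units; within the scatter)). Compound 4 also stands clearly apart from the two other compounds (a 4.9-fold lower number from compound 2 to compound 4 (0.69 log units; beyond the scatter); a 15-fold lower number from compound 1 to compound 4 (1.18 log units; beyond the scatter)), so compound 2, with its 4-chlorophenyl, now has a higher number than both compound 3 and compound 4, and compound 1, with only hydrogen at this carbon, has the highest number of all. The atom and the substituent's place changed together in the step to compound 4, so that step cannot show what either change does alone.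

No measurement here explains these differences. Still open, on these data alone, is how this assay (this assay) would read a sulfur-bearing group with its substituent where compound 3 has it, or an outer ring carrying an amine, a carboxylic acid or a longer chain.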